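A few compounds are considered here, and "the series" means these few. Any claim that something is new, unique, unknown or untested is made for them only; others in the source may bear on it.

Compound 1 `CCCOc1nc(N)nc2c1ncn2/C=C1/CC1(CO)CO` is the reference point of the series. In an ADME assay on BCBL1 cells (Homo sapiens) for cytotoxicity, with a stated time of 7 days (a lower number here means that less compound is tolerated, a higher number that more compound is tolerated), compound 1 gives > 20000 nM, which is a limit of the assay and not a number. Among the compounds with values here, compound 2 `Nc1nc2c(ncn2/C=C2/CC2(CO)CO)c(=O)[nH]1` is the only other compound with a result. In this assay compound 2 gives > 20000 nM, again a limit rather than a number. The whole picture so far is therefore (the limit of > 20000 nM in this assay, at which 2 of the 2 values shown sit), so no step between measured compounds can be drawn, and compound 1 cannot be placed above or below any other compound on the numbers shown. Compound 3 `COCCOc1nc(N)nc2c1ncn2/C=C1/CC1(CO)CO` is not yet measured; it differs from compound 1 by methoxy in place of methyl on a saturated chain carbon, two bonds along the chain from an oxygen on an aromatic ring. With both measured values at the limit, no direction can be read from them, and no step beyond the scatter is expected for this change in this assay. Compound 3 is expected to give about 30000 nM in this assay, with a range from 15000 nM to 80000 nM. The expected step, a step that the limit leaves unreadable from compound 1 to compound 3, would most likely again be reported only as a limit.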

Compound 3, half-maximal cytotoxic concentration: > 20000 nM
Compound 3: only a limit was reported (the forecaster's own chance of this, stated with the estimate: 80%); the middle value does not contradict the limit.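

No step can be read from compound 1 to compound 3 in this assay, since both results are limits and not numbers: the limit of > 20000 nM in this assay, at which 3 of the 3 values shown sit. The compounds shown leave open whether methoxy in place of methyl changes the tolerated concentration at all, and how the three compounds rank.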